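Adding a second chloro to compound 3

The source may hold more compounds than are shown below. What is called first, only, known or untested is meant among the compounds shown, and "the series" means these compounds.

Compound 3 `COc1cc(-n2ncnc2-c2cccc(Cl)c2)cc(OC)c1OC` sits at the limit of a functional assay on K562 cells (Homo sapiens) for antiproliferative activity, read by MTT assay, with a stated time of 72 h (on this read-out higher numbers stand for weaker inhibition and lower numbers for stronger inhibition), where it gives > 10000 nM, a limit of the assay rather than a number. Compound 1 `COc1ccc(-c2ncnn2-c2cc(OC)c(OC)c(OC)c2)cc1` gives 950 nM in this assay. Compound 2 `COc1cc(-n2ncnc2-c2ccc(Cl)cc2)cc(OC)c1OC` gives > 10000 nM, again a limit. Both chloro-bearing compounds thus share the same limit (the limit of > 10000 nM in this assay, at which 2 of the 3 values shown sit). The step of an at least 10-fold higher number from compound 1 to compound 2 (1.02 log units; beyond the scatter) and the step of an at least 10-fold higher number from compound 1 to compound 3 (1.02 log units; beyond the scatter) are both large losses of potency when chloro replaces methoxy on an aromatic carbon; the step that the two limits leave unreadable from compound 2 to compound 3, lying between two limits, cannot be read. Compound 4 `COc1cc(-n2ncnc2-c2ccc(Cl)c(Cl)c2)cc(OC)c1OC` differs from compound 3 by chloro in place of hydrogen on an aromatic carbon, so that a 3,4-dichlorophenyl stands in place of the 3-chlorophenyl. Among the measured compounds shown here, no measured step adds a chloro to a ring that already carries one, so the only guidance is that every chloro-bearing compound so far sits at the limit. Compound 4 is therefore expected to stay at the limit, with the step that the limit leaves unreadable from compound 3 to compound 4 expected to be unreadable. Compound 4 is estimated at 15000 nM, between 5000 nM and 50000 nM.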

Compound 4, half-maximal inhibitory concentration: > 10000 nM
Compound 4: only a limit was reported; the forecaster's own chance of this, stated with the estimate: 80%; the middle value is on the limit's open side.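

Compound 4 shows that a second chloro, placed ortho to a chloro group, does not bring the ring back into the measurable range, and the limit now holds for the 4-chloro, the 3-chloro and the 3,4-dichloro rings alike: the limit of > 10000 nM in this assay, at which 3 of the 4 values shown sit. The change to 3,4-dichlorophenyl in place of 4-methoxyphenyl gives an at least 10-fold higher number from compound 1 to compound 4 (1.02 log units; beyond the scatter), so the large loss seen with one chloro remains with two. The steps among compound 2, compound 3 and compound 4 lie between limits and cannot be read, so any effect of the added chloro stays hidden.

The compounds shown leave open how far past the limit each chloro-bearing compound lies. They also leave open whether the methoxy group itself is needed on this ring, or whether an ethoxy group, a hydroxy group or an amine in its place would keep the activity of compound 1.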